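The compounds below may be only part of what the source reports. "The series", "measured", "known", "first", "only" and "open" are said of these compounds alone.

Measured so far in an assay on isolated protein for inhibition of serine/threonine-protein kinase TBK1 (Homo sapiens); a higher number here means a weaker inhibitor, a lower number a stronger inhibitor:
compound 1, `CCc1cnc(Nc2cccc(F)c2)nc1NCCCNC(=O)C1CCC1`: 63 nM
compound 2, `O=C(NCCCNc1nc(Nc2cccc(F)c2)ncc1Br)C1CCC1`: 2 nM

Compound 2 gives the lowest number of the two; its nearest neighbour is compound 1, and the step of a 32-fold lower number from compound 1 to compound 2 (1.50 log units; beyond the scatter) lies beyond the scatter.

Compound 3, `O=C(NCCCNc1nc(Nc2cccc(F)c2)ncc1CC1CC1)C1CCC1`, has not yet been measured. It differs from compound 2 in one place: cyclopropylmethyl in place of bromo on an aromatic carbon.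

For the measured compounds named here, the only measured step that bears on this change is the one from compound 1 to compound 2, where bromo took the place of ethyl on the same aromatic carbon and the number fell by a 32-fold lower number from compound 1 to compound 2 (1.50 log units; beyond the scatter). Compound 3 moves the other way, taking a carbon-only group, cyclopropylmethyl, back in place of bromo. Because the change from ethyl to bromo gave a 32-fold lower number from compound 1 to compound 2 (1.50 log units; beyond the scatter), the reverse kind of change is expected to raise the number, though how a three-membered ring on a single carbon compares with ethyl is not known from these two compounds.

Compound 3 is therefore estimated at 80 nM, with a range of 20 nM to 300 nM, an expected step of a 40-fold higher number from compound 2 to compound 3 (1.60 log units; beyond the scatter) from compound 2.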

Compound 3, half-maximal inhibitory concentration: > 1000 nM
Compound 3 gave a limit, no number; the forecaster's own chance of this, stated with the estimate: 2%; middle value at least 12-fold (1.09 log units) away from the limit.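

In this assay compound 3 gives > 1000 nM, which is a limit of the assay and not a number. On this aromatic carbon, para to a (3-fluorophenyl)amino group, cyclopropylmethyl in place of bromo brings an at least 500-fold higher number from compound 2 to compound 3 (2.69 log units; beyond the scatter), a larger step than the one seen earlier between ethyl and bromo, so this position tolerates far less change than the first two compounds could show. The two groups made only of carbon also differ widely, with an at least 15-fold higher number from compound 1 to compound 3 (1.20 log units; beyond the scatter), which shows that having no halogen at this position does not by itself set the number, as the earlier pair had left possible.

From the compounds shown here alone, whether the loss follows from the three-membered ring or from the length of the group stays open, as does whether propyl, a cyclopropyl ring bound directly to the aromatic carbon, chloro or a nitrile would stay close to compound 2 at 2 nM. How far compound 3 lies past the limit is also unknown, and both new steps are bounded on one side only: the limit of > 1000 nM in this assay, at which 1 of the 3 values shown sits.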